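This account rests on a few compounds, and the source may have more. Where it says the series, first, only, none or still open, it means among the compounds named here.

In a functional assay on CCRF-CEM cells (Homo sapiens) for inhibition (on this read-out higher numbers stand for weaker inhibition and lower numbers for stronger inhibition), compound 1 (`Nc1nc(O)c2ncn([C@@H]3O[C@@H](CO)C=C3F)c2n1`) gives > 100000 nM, which is a limit of the assay and not a number. Compound 2 (`Nc1nc(Cl)c2ncn([C@H]3O[C@@H](CO)C=C3F)c2n1`) gives > 100000 nM, which is likewise a limit. Compound 2 therefore stands at the limit of > 100000 nM in this assay, at which 2 of the 2 values shown sit, and no number fixes its place. Compound 3 (`Nc1nc(Cl)c2ncn([C@@H]3O[C@@H](CO)C=C3F)c2n1`) departs from compound 2 in a single respect: the two compounds have the same atoms and bonds and differ only in configuration as drawn: 1 of 2 stereo elements differ; a stereocentre at a saturated ring carbon is drawn S in compound 2 and R in compound 3. The atoms and bonds stay the same, and only that stereocentre at a saturated ring carbon changes, from S to R. The expected step, an at least 1.1-fold lower number from compound 2 to compound 3 (0.04 log units; that floor lies within the scatter), is estimated to be small, at most a modest move towards stronger inhibition, and the reading may well remain a limit. This expectation has only the limit of compound 2 at > 100000 nM to rest on. For compound 3 the estimated value is 90000 nM, with an expected range of 25000 nM to 150000 nM.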

Compound 3, half-maximal inhibitory concentration: 28200 nM
The estimate for compound 3 lay 3.2-fold (0.50 log units) above the measured number, and the stated range covers the measured number.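

In this assay, among these compounds, compound 3 gives the first reading that is a number, and it shows that the stereocentre at a saturated ring carbon counts here, since the change from S to R alone brings an at least 3.5-fold lower number from compound 2 to compound 3 (0.54 log units; beyond the scatter); the step can be laid on that centre for one reason: the fact that compounds 2 and 3 differ only in the configuration as drawn. With that configuration kept, chloro in place of hydroxy on an aromatic carbon brings an at least 3.5-fold lower number from compound 1 to compound 3 (0.54 log units; beyond the scatter). Both steps start from limits of the assay, so each gives only a floor and the full size of neither is fixed.

From the compounds shown here alone, whether bromo, methoxy or an amine in place of the chloro would lower the number further remains open. Also open, going by these compounds, are whether chloro in place of hydroxy has any such step with the stereocentre drawn S, and what lies behind the preference for R.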